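The compounds below may be only part of what the source reports. "The series", "measured", "known", "first", "only" and "open" are said of these compounds alone.

Compound 1 (`CN(Cc1ccc(OCCCN)cc1)c1nc2ccc(Oc3ccc(C#N)cc3)cc2s1`) was tested in an assay on SH-SY5Y cells for inhibition of Voltage-dependent N-type calcium channel subunit alpha-1B (Homo sapiens), read by FLIPR and calcium flux, with stated times of 600 s and 300 s, in the presence of a further agent that is not named here (on this read-out lower numbers stand for stronger inhibition and higher numbers for weaker inhibition), where compound 1 gives 65000 nM. For the measured compounds named here, this is the highest of the two numbers measured so far; the nearest is compound 2 (`CN(Cc1ccc(OCCCN)cc1)c1nc2ccc(Oc3ccccc3)cc2s1`), which in this assay gives 49000 nM, and the step of a 1.3-fold lower number from compound 1 to compound 2 (0.12 log units; within the scatter), hydrogen in place of cyano on an aromatic carbon, lies within the scatter. Compound 3 (`CN(Cc1ccc(OCCCNC(=N)N)cc1)c1nc2ccc(Oc3ccc(C#N)cc3)cc2s1`) has not yet been measured. It differs from compound 1 in one place: a group of 3 heavy atoms (1 carbon, 2 nitrogen; no ring) in place of a hydrogen atom, on an amine nitrogen. Going by the values given here, the only measured step, a 1.3-fold lower number from compound 1 to compound 2 (0.12 log units; within the scatter), concerns a group on an aromatic carbon and not the amine nitrogen, so no measured step bears on this change. Without such guidance, the expectation is a step of no clear direction and not beyond the scatter. Compound 3 is therefore estimated at 45000 nM, with a range from 12000 nM to 170000 nM, which corresponds to an expected step of a 1.4-fold lower number from compound 1 to compound 3 (0.16 log units; within the scatter).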

Compound 3, half-maximal inhibitory concentration: 143000 nM
Beside the measured number, compound 3's estimate is 3.2-fold (0.50 log units) below it; measured number inside the range.
By their numbers in this assay, from the lowest: compounds 2 and 1 (each within the scatter of the next); then compound 3.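

On the amine nitrogen, a group of 3 heavy atoms (1 carbon, 2 nitrogen; no ring) in place of a hydrogen atom gives a 2.2-fold higher number from compound 1 to compound 3 (0.34 log units; beyond the scatter) in this assay and so weakens inhibition modestly. The earlier step on an aromatic carbon stayed within the scatter, whereas this one is the first shown to lie beyond it, which marks the amine nitrogen as a place where a change can register in this assay. No measurement shown here accounts for the shift.
As far as these compounds go, it remains open whether a smaller group on the same nitrogen, such as a methyl or an acetyl group, or a longer chain carrying the amine, would move the number in the same direction. From the compounds shown here alone, it is also open whether the same replacement would have a similar effect on compound 2, which has hydrogen in place of cyano.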